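A Shorter Amide on a Rearranged Sulfonamide Core

The source may report more compounds than this note shows. Statements on the series, on what has been measured and on what is new or still open speak of the compounds shown alone.

In a functional assay on the whole organism with Mus musculus as the target, with a stated time of 30 min (on this read-out lower numbers stand for an effect already at smaller amounts and higher numbers for an effect only at larger amounts of compound), compound 1 `CC(=O)NC1CCN(S(=O)(=O)c2ccc(F)cc2)CC1` gives 0.01 mg/kg. Compound 3 `CCC(=O)NC1CCN(S(=O)(=O)c2ccc(F)cc2)CC1` gives 0.1 mg/kg in this assay, and compound 2 `CCC(=O)N1CCCC(NS(=O)(=O)c2ccc(F)cc2)C1` gives 10 mg/kg, the highest of the three numbers, standing well apart from both others. Compound 2 and compound 3 are built from the same atoms joined differently; the difference between the two cores is not broken down here. Within the core shared by compound 1 and compound 3, the step of a 10-fold lower number from compound 3 to compound 1 (1.00 log units; beyond the scatter) accompanies the change hydrogen in place of methyl on a saturated chain carbon bound to a carbonyl carbon Compound 4 `CC(=O)N1CCCC(NS(=O)(=O)c2ccc(F)cc2)C1` carries the same kind of change on the core of compound 2: hydrogen in place of methyl on a saturated chain carbon bound to a carbonyl carbon The two places read the same word for word, and the change occurs twice among these compounds, once with a measured result. If the step seen from compound 3 to compound 1 carries over to the other core, compound 4 is expected to show a 10-fold lower number from compound 2 to compound 4 (1.00 log units; beyond the scatter), an expectation resting on a 10-fold lower number from compound 3 to compound 1 (1.00 log units; beyond the scatter) and on the value of compound 2 10 mg/kg. The different core leaves room for doubt, so the estimate is kept broad: compound 4 is expected at 1 mg/kg, between 0.2 mg/kg and 10 mg/kg.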

Compound 4, minimum effective dose: 1 mg/kg
Compound 4: middle estimate and measured number agree at the digits printed; measured number inside the range.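

The second core repeats the step: going from propanoyl to acetyl gives a 10-fold lower number from compound 2 to compound 4 (1.00 log units; beyond the scatter) in this assay. Set beside the earlier step, the same change reads alike on both cores, with no difference beyond the scatter: the same change on two cores in this assay, a 10-fold lower number (1.00 log units; beyond the scatter) from compound 3 to compound 1 and a 10-fold lower number (1.00 log units; beyond the scatter) from compound 2 to compound 4, 1.0-fold (0.00 log units) apart, within the scatter of two such steps. Going by these compounds alone, this shows that the change carried over between these two cores in this read-out, but it rests on only two pairs, so it does not show that the step would hold on any further core, and it gives no reason why the change acts as it does.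

Left open is how a longer chain such as butanoyl, or a branched one such as isobutyryl, would read on either core, and whether an amine or a carboxylic acid at the end of the chain would follow the same line. Also open, on these data alone, is whether chlorine or a methoxy group could stand in place of the fluorine with the step between propanoyl and acetyl unchanged.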